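The source may report more compounds than this note shows. Statements on the series, on what has been measured and on what is new or still open speak of the compounds shown alone.

Compound 1, `CSc1ncnc2c1c(-c1ccsc1)cn2[C@@H]1O[C@H](CO)[C@@H](O)[C@H]1O`, gives > 20000 nM in a functional assay on HCT-116 cells (Homo sapiens), read by MTT assay, with a stated time of 72 h (a lower number here means a stronger inhibitor, a higher number a weaker inhibitor), which is a limit and not a number. Compound 2, `CSc1ncnc2c1c(-c1ccccc1)cn2[C@@H]1O[C@H](CO)[C@@H](O)[C@H]1O`, gives > 20000 nM in this assay, and this too is only a limit. Compound 2 therefore has no exact position on the scale, and the picture so far is the limit of > 20000 nM in this assay, at which 2 of the 2 values shown sit.

Compound 3, `C#Cc1cn([C@@H]2O[C@H](CO)[C@@H](O)[C@H]2O)c2ncnc(SC)c12`, differs from compound 2 by a single change: ethynyl in place of phenyl on an aromatic carbon. In words, a small ethynyl replaces the phenyl ring, so compound 3 carries no ring at this place.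

For the measured compounds named here, the only measured step that bears on this change is a step that the two limits leave unreadable from compound 1 to compound 2. It has no size that can be carried over, and it compares one ring with another, so it offers only a weak guide to a group without a ring.

Since the starting point is a limit, a readable result could only lie toward stronger inhibition, yet compound 3 may stay at the limit as well. The expected change, held with low confidence, is an at least 3.3-fold lower number from compound 2 to compound 3 (0.52 log units; beyond the scatter). For compound 3 the estimated value is 6000 nM, within an expected range of 400 nM to 20000 nM.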

Compound 3, half-maximal inhibitory concentration: 90 nM
For compound 3 the middle estimate is 67-fold (1.82 log units) above the measured one; measured number outside the range, below it.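

This position tolerates very different outcomes in this assay, and the group on this aromatic carbon decides between them: ethynyl in place of phenyl gives an at least 220-fold lower number from compound 2 to compound 3 (2.34 log units; beyond the scatter), and ethynyl in place of thiophen-3-yl gives an at least 220-fold lower number from compound 1 to compound 3 (2.34 log units; beyond the scatter). Compounds 1 and 2 could not be told apart, as each gives only a limit, whereas these two steps can be read, and each has a printed size that is a minimum and not an exact figure. Both compounds with a ring at this place remain at the limit, and the only compound shown with a readable value carries a small ethynyl group and no ring, so this contrast rests on a single compound: the limit of > 20000 nM in this assay, at which 2 of the 3 values shown sit.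

Whether the triple bond itself matters, or only the loss of the ring, stays open, since a vinyl or an ethyl group on this carbon would separate the two and neither is among the compounds shown. On these data alone, it is also open how a nitrile or a longer chain such as propynyl would behave at this place.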